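The source may report more compounds than this note shows. Statements on the series, on what has been measured and on what is new or still open speak of the compounds shown alone.

In an ADME assay on A2780 cells (Homo sapiens) for antiproliferative activity (a higher number here means a weaker inhibitor, a lower number a stronger inhibitor), two compounds have been measured so far:

- compound 1 `C=C1C(=O)C[C@@H]2[C@@H](C)[C@@H]3C=CC(=O)[C@@]3(C)[C@@H](OC(=O)/C(C)=C\C)[C@H]1[C@H]2OC(=O)CC(C)(C)O`: 570 nM
- compound 2 `C=C1C(=O)C[C@@H]2[C@@H](C)[C@@H]3C=CC(=O)[C@@]3(C)[C@@H](OC(=O)/C(C)=C\C)[C@H]1[C@H]2OC(=O)CC(C)(O)CC`: 380 nM

Within the data shown here, compound 2, at 380 nM, cannot be separated from compound 1, since the only measured step is a 1.5-fold lower number from compound 1 to compound 2 (0.18 log units; within the scatter). Compound 3 `C=C1C(=O)C[C@@H]2[C@@H](C)[C@@H]3C=CC(=O)[C@@]3(C)[C@@H](OC(=O)/C=C(\C)CC)[C@H]1[C@H]2OC(=O)CC(C)(O)CC` shares the core of compound 2 and differs from it in one group: 2-methylbut-1-en-1-yl in place of 1-methylprop-1-en-1-yl on a carbonyl carbon. In words, 2-methylbut-1-en-1-yl stands in place of 1-methylprop-1-en-1-yl on a carbonyl carbon whose other neighbours are: oxygen next to a carbonyl group.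

Among the measured compounds shown here, no measured step covers this change directly. The closest evidence is a 1.5-fold lower number from compound 1 to compound 2 (0.18 log units; within the scatter), which also adds carbon but does so elsewhere, as methyl in place of hydrogen on a saturated chain carbon. This single step is weak support, yet it gives no reason to expect a shift beyond the scatter in this assay, in either direction. The expected result is a 1.1-fold higher number from compound 2 to compound 3 (0.02 log units; within the scatter). The estimated value for compound 3 is 400 nM, with an expected range of 160 nM to 1000 nM.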

Compound 3, half-maximal inhibitory concentration: 1900 nM
Compound 3: middle estimate off by 4.8-fold (0.68 log units), on the low side, outside the stated range (above it).
By their numbers in this assay, from the lowest: compounds 2 and 1 (each within the scatter of the next); then compound 3.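

Placing 2-methylbut-1-en-1-yl (5 heavy atoms) in place of 1-methylprop-1-en-1-yl (4 heavy atoms) on this carbonyl carbon gives a 5.0-fold higher number from compound 2 to compound 3 (0.70 log units; beyond the scatter) in this assay, so this position responds beyond the scatter, whereas the one earlier step, on a saturated chain carbon elsewhere in the molecule, stayed within it. The two groups match in having no ring, one double bond, no hydrogen-bond donors or acceptors and no net charge, which leaves the heavy-atom count as the only one of these counts that separates them. No independent measurement bears on why the number rises at this position.

On these data alone, this is a single step, so it remains open whether the trend would continue with a longer chain such as a hexenyl group, or whether a saturated butyl chain or a phenyl ring on the same carbonyl carbon would behave alike. Among these compounds, it is also open whether the same exchange would give a step of similar size with the other ester of compound 1 in place of the one in compound 2.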